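Swapping a Pyridinyl for a tert-Butyl on an Amide Nitrogen

The compounds below may be only part of what the source reports. "The series", "measured", "known", "first", "only" and "open" are said of these compounds alone.

Of the compounds shown here, three built on the same core have been tested in an assay on HEK293 cells for agonist activity at transient receptor potential cation channel subfamily M member 8 (Homo sapiens), read by fluorescence and calcium flux, with a stated time of 15 min; a higher number here means that more compound is needed for the effect, a lower number that less compound is needed. Compound 1 `Cc1ccc(OCC(=O)N(Cc2cccs2)c2cccnc2)cc1` gives 198 nM, the highest number of the three. Compound 2 `CCN(Cc1cccs1)C(=O)COc1cc(C)ccc1O` gives 24 nM, and compound 3 `CCN(Cc1ccsc1)C(=O)COc1ccc(C)cc1` gives 88 nM. Both compounds 2 and 3 carry an ethyl group on the amide-type nitrogen instead of the aromatic ring of compound 1, but each also differs from compound 1 elsewhere, so no single change can be singled out from their numbers.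

Compound 4 `Cc1ccc(OCC(=O)N(Cc2cccs2)C(C)(C)C)cc1` has not yet been measured. It differs from compound 1 in one place: tert-butyl in place of pyridin-3-yl on an amide-type nitrogen. A small, non-aromatic group thus replaces the ring on the amide-type nitrogen.

Compound 4 is expected to give a somewhat lower number than compound 1 in this assay, a step of a 2.0-fold lower number from compound 1 to compound 4 (0.30 log units; within the scatter) that goes beyond the scatter, because compound 3, with a small alkyl group in that place, gives 88 nM. The estimate for compound 4 is 100 nM, with a range from 30 nM to 400 nM.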

Compound 4, half-maximal effective concentration: 11000 nM
Compound 4: middle estimate off by 110-fold (2.04 log units), on the low side, and the stated range ends below it.
By their numbers in this assay, from the lowest: compound 2; then compound 3; then compound 1; then compound 4.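

In this assay, for the compounds shown here, the change on the amide-type nitrogen gives a 56-fold higher number from compound 1 to compound 4 (1.74 log units; beyond the scatter) and, with only this one place differing, offers the first clean reading of this position. Compounds 2 and 3 each differ from compound 1 in more than one place, so they could not show that exchanging pyridin-3-yl for tert-butyl, with the rest of the structure unchanged, can shift the number this far. The data shown include no measurement that explains the size of this rise.

On these data alone, it remains open whether the rise follows from losing the ring, losing its ring nitrogen or introducing tert-butyl itself. Phenyl, cyclohexyl or isopropyl in this place on the core of compound 1 would help separate these three possibilities.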